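A few compounds are considered here, and "the series" means these few. Any claim that something is new, unique, unknown or untested is made for them only; others in the source may bear on it.

Measured compounds:
compound 1, `COc1ccc(C(=O)/C=C/c2cc3ccccc3[nH]c2=O)cc1`, giving 3360 nM in a functional assay on HL-60 cells (Homo sapiens) for cytotoxicity, read by sulforhodamine B assay, with a stated time of 24 h; a higher number here means a weaker inhibitor of growth, a lower number a stronger inhibitor of growth
compound 2, `O=C(/C=C/c1cc2ccccc2[nH]c1=O)c1ccc(O)cc1`, giving 2660 nM in this assay

Compound 2 stands at the lowest of the two numbers in this assay, with compound 1 nearest to it. Among the measured compounds shown here, the only measured step, a 1.3-fold lower number from compound 1 to compound 2 (0.10 log units; within the scatter), lies within the scatter, so the two values do not separate the two compounds.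

Compound 3, `O=C(/C=C/c1cc2ccccc2[nH]c1=O)c1ccc(Cl)cc1`, differs from compound 2 in a single place: chloro in place of hydroxy on an aromatic carbon. For the measured compounds named here, no measured step covers this exchange. Going by the values given here, the one step that exists concerns the same group on the same aromatic ring, and it was small, so the data give no indication that a change at this position moves the number in this assay by more than the scatter. The expectation for compound 3 is therefore a value close to that of compound 2, with no step beyond the scatter in either direction.

On that basis compound 3 is estimated at 2500 nM in this assay, with a range from 900 nM to 7000 nM. The expected step is a 1.1-fold lower number from compound 2 to compound 3 (0.03 log units; within the scatter).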

Compound 3, concentration for 50% growth inhibition: 2470 nM
The estimate for compound 3 lay 1.0-fold (0.01 log units) above the measured number, within the range that was stated.
By their numbers in this assay, from the lowest: compounds 3, 2 and 1 (each within the scatter of the next).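

Across this assay, the exchange of 4-hydroxyphenyl for 4-chlorophenyl gives a 1.1-fold lower number from compound 2 to compound 3 (0.03 log units; within the scatter) and the exchange of methoxy for chloro gives a 1.4-fold lower number from compound 1 to compound 3 (0.13 log units; within the scatter) at the same aromatic carbon, para to a large group. Methoxy, hydroxy and chloro therefore all stand within the scatter of one another at this carbon, a wider sweep than the single step between the two oxygen-linked groups could show. Chloro, with 0 hydrogen-bond donors and 0 hydrogen-bond acceptors, gives a number that cannot be told from that of hydroxy, so the hydrogen-bond donor and acceptor counted for hydroxy make no visible difference in this set of compounds, and nothing at hand bears on why the number holds steady. 

It remains open whether an amine, a carboxylic acid or a longer chain at this carbon would move the number beyond the scatter, since the three groups shown do not test this. Also open, on these data alone, is whether any change to the shared core would produce a step larger than those seen here.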